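This account rests on a few compounds, and the source may have more. Where it says the series, first, only, none or still open, it means among the compounds named here.

Of the compounds shown here, three with a shared core have been measured in an assay on isolated protein for binding affinity to histamine H2 receptor (Homo sapiens); on this read-out higher numbers stand for weaker inhibition and lower numbers for stronger inhibition. Compound 1 `CCOC(=O)N1CCN(CCCOc2ccc(C(C)=O)cc2)CC1` gives 39800 nM. Compound 2 `CCOC(=O)N1CCN(CCCOc2ccc(C(=O)c3ccc(F)cc3)cc2)CC1` gives 42700 nM in this assay, and the step of a 1.1-fold higher number from compound 1 to compound 2 (0.03 log units; within the scatter) shows that the two numbers lie within the scatter. Compound 3 `CCOC(=O)N1CCN(CCCOc2ccc(C(=O)c3ccc(C(C)(C)C)cc3)cc2)CC1` gives 1550 nM in this assay, the lowest of the three numbers, which on this read-out means the strongest inhibition. The two steps leading to it were large: a 26-fold lower number from compound 1 to compound 3 (1.41 log units; beyond the scatter) and a 28-fold lower number from compound 2 to compound 3 (1.44 log units; beyond the scatter). Compound 4 `CCOC(=O)N1CCN(CCCOc2ccc(C(=O)/C=C/c3ccc(OC)cc3)cc2)CC1` has not yet been measured; it differs from compound 3 by 2-(4-methoxyphenyl)ethenyl in place of 4-(tert-butyl)phenyl on a carbonyl carbon. The entering group keeps an aromatic ring but lacks tert-butyl, and compound 2 shows that an aromatic ring without it left the number high, at 42700 nM, while the step of a 28-fold lower number from compound 2 to compound 3 (1.44 log units; beyond the scatter) shows how much tert-butyl mattered. For compound 4 a moderate rise in the number is therefore expected, a 5.2-fold higher number from compound 3 to compound 4 (0.71 log units; beyond the scatter), without a return to the level of compound 2. Compound 4 is estimated at 8000 nM, in the range from 2000 nM to 30000 nM.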

Compound 4, inhibition constant: 6760 nM
Compound 4: middle estimate off by 1.2-fold (0.07 log units), on the high side; the measured number falls inside the stated range.
By their numbers in this assay, from the lowest: compound 3; then compound 4; then compounds 1 and 2 (each within the scatter of the next).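

On this carbonyl carbon, tert-butyl is not the only feature that can lower the number in this assay: the 2-(4-methoxyphenyl)ethenyl group also gives a clear drop, both against methyl (a 5.9-fold lower number from compound 1 to compound 4 (0.77 log units; beyond the scatter)) and against 4-fluorophenyl (a 6.3-fold lower number from compound 2 to compound 4 (0.80 log units; beyond the scatter)). It does not fully match 4-(tert-butyl)phenyl, however (a 4.4-fold higher number from compound 3 to compound 4 (0.64 log units; beyond the scatter)), so compound 3 keeps the lowest number of the four. No measurement shown explains why these groups shift the number.

The group in compound 4 differs from 4-fluorophenyl in both its double bond and its methoxy group, so the source of the gain remains unresolved. Placing 4-methoxyphenyl directly on the carbonyl carbon, or using 2-(4-methoxyphenyl)ethyl without the double bond, would help separate those two features.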